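Dropping the side-chain oxygen: from compound 2 to compound 4

The source may hold more compounds than are shown below. What is called first, only, known or untested is meant among the compounds shown, and "the series" means these compounds.

Three measured compounds share one core and differ only in a short saturated side chain. Compound 1 `COC[C@H](C)[C@H](C)C(c1ccc(O)c(OC)c1)c1ccc(O)c(OC)c1` carries a methoxy on that chain and in a functional assay on HL-60 cells (Homo sapiens) for cytotoxicity, read by WST assay, with a stated time of 48 h (a lower number here means a stronger inhibitor, a higher number a weaker inhibitor), gives 82000 nM. Compound 3 `COc1cc(C(c2ccc(O)c(OC)c2)[C@@H](C)[C@@H](C)CF)ccc1O` carries a fluoro there and in this assay gives 38000 nM. Compound 2 `COc1cc(C(c2ccc(O)c(OC)c2)[C@@H](C)[C@@H](C)CO)ccc1O` carries a hydroxy, and in this assay compound 2 gives only a limit, > 100000 nM, so its true value is not known beyond (the limit of > 100000 nM in this assay, at which 1 of the 3 values shown sits).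

Compound 4 `CC[C@H](C(C)C)C(c1ccc(O)c(OC)c1)c1ccc(O)c(OC)c1` has no oxygen in the side chain at all: 1-isopropylpropyl in place of 2-(hydroxymethyl)-1-methylpropyl on a saturated chain carbon bound to two aromatic carbons. Among the measured compounds shown here, two measured steps bear on this. Replacing methoxy with hydroxy gave an at least 1.2-fold higher number from compound 1 to compound 2 (0.08 log units; that floor lies within the scatter), while replacing hydroxy with fluoro gave an at least 2.6-fold lower number from compound 2 to compound 3 (0.42 log units; beyond the scatter), and methoxy with fluoro gave a 2.2-fold lower number from compound 1 to compound 3 (0.33 log units; beyond the scatter). The numbers move downward as the chain loses its hydroxy, so removing the oxygen entirely is expected to bring a modest downward step as well, though the limit on compound 2 leaves the size uncertain.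

Compound 4 is therefore expected to give about 40000 nM in this assay, within a range of 15000 nM to 100000 nM. That expectation corresponds to an at least 2.5-fold lower number from compound 2 to compound 4 (0.39 log units; beyond the scatter).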

Compound 4, half-maximal inhibitory concentration: 16000 nM
Compound 4: the middle estimate sits 2.5-fold (0.40 log units) above what was measured; low and high end bracket the measured number.
By their numbers in this assay, from the lowest: compound 4; then compound 3; then compound 1. At a limit, above all of these: compound 2.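

With a side chain of carbon and hydrogen alone, compound 4 has the lowest number of the four in this assay, so neither the oxygen nor the fluoro on this chain is needed for that activity on the shared core. The 1-isopropylpropyl group goes further than the fluoro chain, with a 2.4-fold lower number from compound 3 to compound 4 (0.38 log units; beyond the scatter) and, against the methoxy chain, a 5.1-fold lower number from compound 1 to compound 4 (0.71 log units; beyond the scatter) on a saturated chain carbon bound to two aromatic carbons. Against the hydroxy chain the step is an at least 6.2-fold lower number from compound 2 to compound 4 (0.79 log units; beyond the scatter) and gives only a floor, not a size, because compound 2 stands at a limit of the assay: (the limit of > 100000 nM in this assay, at which 1 of the 4 values shown sits).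

The compounds shown leave open whether an amine or a carboxylic acid on this chain would keep the number low, and whether a longer chain would take it lower still. Going by these compounds, this change also swaps more than one feature at once, going from 2 defined stereocentres to 1 and rearranging the carbons as well as removing the oxygen, so the share of each in the lower number remains unknown.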